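Branching the hydroxyalkyl chain on compound 3's ring nitrogen

The source may report more compounds than this note shows. Statements on the series, on what has been measured and on what is new or still open speak of the compounds shown alone.

Three compounds share one core and differ only in the group on a nitrogen on an aromatic ring. Compound 1 `Cc1nc(NC2CCCC2)c2cc[nH]c2n1` gives 72400000 nM in a functional assay on the whole organism for inhibition, with Nicotiana tabacum as the target; on this read-out lower numbers stand for stronger inhibition and higher numbers for weaker inhibition. Compound 2 `C=CCNc1nc(C)nc2[nH]ccc12` gives 676000000 nM, and compound 3 `Cc1nc(NCCCO)c2cc[nH]c2n1` gives 17800000 nM, the lowest of the three numbers. The measured steps are a 9.3-fold higher number from compound 1 to compound 2 (0.97 log units; beyond the scatter), a 4.1-fold lower number from compound 1 to compound 3 (0.61 log units; beyond the scatter) and a 38-fold lower number from compound 2 to compound 3 (1.58 log units; beyond the scatter).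

Compound 4 `Cc1nc(NC(C)(C)O)c2cc[nH]c2n1` differs from compound 3 by 1-hydroxy-1-methylethyl in place of 3-hydroxypropyl on a nitrogen on an aromatic ring. The two steps ending at compound 3 both bear on this: the hydroxyl-bearing chain gave the lowest number, and compound 3 stands beyond the scatter from both compound 1 and compound 2. Among the compounds with values here, none of the measured steps, however, tests a branched group of this kind against a straight chain, so the direction of the change is not settled by the data. A modest weakening is expected, since a 4.1-fold lower number from compound 1 to compound 3 (0.61 log units; beyond the scatter) shows that a change of the group with the hydroxyl kept shifts the number moderately. Compound 4 is therefore estimated at 35000000 nM, with a range from 10000000 nM to 120000000 nM, which means an expected step of a 2.0-fold higher number from compound 3 to compound 4 (0.29 log units; within the scatter).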

Compound 4, half-maximal inhibitory concentration: 166000000 nM
For compound 4 the middle estimate is 4.7-fold (0.68 log units) below the measured one; measured number above the stated range.
By their numbers in this assay, from the lowest: compound 3; then compound 1; then compound 4; then compound 2.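

With the same atoms on the nitrogen, joined differently, 1-hydroxy-1-methylethyl in place of 3-hydroxypropyl shifts the number in this assay (a 9.3-fold higher number from compound 3 to compound 4 (0.97 log units; beyond the scatter)), so the arrangement of the chain matters here and not only its composition. Keeping a hydroxyl therefore does not by itself hold the number low: the cyclopentyl group gives a lower number than the branched hydroxyl group (a 2.3-fold higher number from compound 1 to compound 4 (0.36 log units; beyond the scatter)), while the allyl group gives a higher one (a 4.1-fold lower number from compound 2 to compound 4 (0.61 log units; beyond the scatter)). Nothing measured here accounts for the shift.

Going by these compounds, whether the low number of compound 3 rests on the hydroxyl or on the straight chain stays open. An unbranched propyl group, an amine in place of the hydroxyl, or a longer hydroxyalkyl chain would each bear on that question.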